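Compound 3: A Longer Chain on the Shared Core

This account rests on a few compounds, and the source may have more. Where it says the series, first, only, none or still open, it means among the compounds named here.

In a functional assay on SW480 cells (Homo sapiens) for antiproliferative activity, read by MTT assay, with a stated time of 48 h (on this read-out higher numbers stand for weaker inhibition and lower numbers for stronger inhibition), compound 1 (`CCCCCCCCCC(CCO)n1cnc2c(Cl)ncnc21`) reads 1150 nM while compound 2 (`CCCCCCCCCCC(CCO)n1cnc2c(Cl)ncnc21`) reads 3160 nM and so holds the higher of the two numbers, which means the weaker inhibition. Compound 3 (`CCCCCCCCCCCCC(CCO)n1cnc2c(Cl)ncnc21`) keeps the shared core and carries ethyl in place of hydrogen on a saturated chain carbon, ten or more bonds along the chain from an aromatic nitrogen. Going by the values given here, only one measured step bears on this change (a 2.7-fold higher number from compound 1 to compound 2 (0.44 log units; beyond the scatter)). That step is modest and is a change of the same kind, with methyl in place of hydrogen. A single step does not make a trend, and the data do not show whether the direction continues or levels off. A further rise of the number is therefore expected, about the size of that step or somewhat more, with a wide margin. The expected change is a step (a 3.2-fold higher number from compound 2 to compound 3 (0.50 log units; beyond the scatter)) in this assay and no more than an estimate. Compound 3 is estimated at 10000 nM (range 3500 nM to 30000 nM).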

Compound 3, half-maximal inhibitory concentration: > 50000 nM
Compound 3 was reported as a limit; the forecaster's own chance of this, stated with the estimate: 10%; at least 5.0-fold (0.69 log units) between middle value and limit.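

Compound 3 is reported in this assay as a limit and not as a number: the limit of > 50000 nM in this assay, at which 1 of the 3 values shown sits.

Even so, ethyl in place of hydrogen on the chain gives an at least 15-fold higher number from compound 2 to compound 3 (1.19 log units; beyond the scatter), a large step where the earlier one, a 2.7-fold higher number from compound 1 to compound 2 (0.44 log units; beyond the scatter), was modest. Taken across the whole series, replacing hydrogen with propyl at this place gives an at least 43-fold higher number from compound 1 to compound 3 (1.63 log units; beyond the scatter), so all three compounds fall in one order, with the number rising as the chain grows and no compound going against it, and the rise does not level off within the lengths shown.

The compounds shown leave open how far past the limit compound 3 truly lies, and whether a shorter chain at this place would give a lower number than compound 1 or whether the order would turn there. They also leave open what an amine or a carboxylic acid on a saturated chain carbon, in place of the added alkyl length, would do in this assay.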